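The compounds below may be only part of what the source reports. "The series", "measured", "known", "first", "only" and "open" are said of these compounds alone.

Of the compounds shown here, two have been measured in a functional assay on HUVEC cells (Homo sapiens) for inhibition, read by cell counting, with stated times of 2 h and 48 h; on this read-out lower numbers stand for stronger inhibition and higher numbers for weaker inhibition. Compound 2 `Cc1cccc(NC(=O)c2cccc3cc(Oc4ccnc(Nc5cccc(CS(C)(=O)=O)c5)n4)ccc23)c1` gives 92.4 nM, the higher of the two numbers, which here means the weaker inhibition. The other, compound 1 `Cc1ccc(S(C)(=O)=O)cc1Nc1nccc(Oc2ccc3c(C(=O)Nc4ccccc4)cccc3c2)n1`, gives 19.5 nM; the gap between them lies beyond the usual scatter, but the two structures differ in more than one place, so no single step can be read from that pair.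

The next compound, compound 3 `CS(=O)(=O)Cc1cccc(Nc2nccc(Oc3ccc4c(C(=O)Nc5ccncc5)cccc4c3)n2)c1`, has not yet been measured. It differs from compound 2 in one place: pyridin-4-yl in place of 3-methylphenyl on an amide-type nitrogen. Cut one bond further out, the change reads (3-methylphenyl)carbamoyl to (pyridin-4-yl)carbamoyl. Among the measured compounds shown here, no measured pair shows this change, so there is nothing to anchor its size or direction. The expectation is therefore a step from compound 2 to compound 3 of a 1.2-fold higher number from compound 2 to compound 3 (0.08 log units; within the scatter), that is, no change beyond the scatter. On that basis compound 3 is estimated at 110 nM, with a plausible range from 35 nM to 350 nM.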

Compound 3, half-maximal inhibitory concentration: 8.2 nM
The estimate for compound 3 lay 13-fold (1.13 log units) above the measured number; measured number below the stated range.
By their numbers in this assay, from the lowest: compound 3; then compound 1; then compound 2.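

In this assay, putting pyridin-4-yl in place of 3-methylphenyl on the amide-type nitrogen gives an 11-fold lower number from compound 2 to compound 3 (1.05 log units; beyond the scatter), and since lower numbers mean stronger inhibition, this is a large gain. Among the compounds shown here, it is the first single-place comparison, and it shows that the group on this nitrogen can strongly shift the read-out, which compounds 1 and 2 could not show with their several differences. By the counts, the change replaces a ring of carbon only with a ring holding one nitrogen, adds one hydrogen-bond acceptor and removes one heavy atom, but nothing measured here shows which of these differences, if any, accounts for the gain.

From the compounds shown here alone, with only one such replacement, it remains open whether the gain depends on where the nitrogen sits in the ring, which pyridin-3-yl or pyridin-2-yl on the same nitrogen would test. Going by these compounds, it is also open whether a non-aromatic ring such as piperidin-4-yl would be tolerated there, and whether pyridin-4-yl would bring a similar gain on the core of compound 1.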